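From 2-chlorophenyl to 4-chlorophenyl: a step awaiting measurement

A few compounds are considered here, and "the series" means these few. Any claim that something is new, unique, unknown or untested is made for them only; others in the source may bear on it.

Compound 1 `COc1cc(OC)c(OC)cc1/C=C/COC(=O)/C=C/c1ccccc1C(F)(F)F` returns a limit and not a number in a functional assay on the whole organism (strain Kunming) with Mus musculus as the target, with a stated time of 0.5 h (on this read-out lower numbers stand for an effect already at smaller amounts and higher numbers for an effect only at larger amounts of compound), > 710 umol/kg. In this assay compound 2 `COc1cc(OC)c(OC)cc1/C=C/COC(=O)/C=C/c1cccc(Br)c1` gives 497 umol/kg. Compound 3 `COc1cc(OC)c(OC)cc1/C=C/COC(=O)/C=C/c1ccccc1Cl` gives 639 umol/kg, which lies within the scatter of compound 2.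

In compound 4 `COc1cc(OC)c(OC)cc1/C=C/COC(=O)/C=C/c1ccc(Cl)cc1`, 4-chlorophenyl stands in place of 2-chlorophenyl on a double-bonded chain carbon bound to a double-bonded chain carbon (4-chlorophenyl in place of 2-chlorophenyl on a double-bonded chain carbon bound to a double-bonded chain carbon). Going by the values given here, no measured step carries this exact change, so the nearest ones must serve. The exchange of 3-bromophenyl for 2-chlorophenyl gives a 1.3-fold higher number from compound 2 to compound 3 (0.11 log units; within the scatter). The exchange of trifluoromethyl for chloro gives an at least 1.1-fold lower number from compound 1 to compound 3 (0.04 log units; that floor lies within the scatter). The step to 3-bromophenyl gives an at least 1.4-fold lower number from compound 1 to compound 2 (0.15 log units; that floor lies within the scatter). None of these shows a change beyond the scatter, so no clear direction is expected in this assay. The expected step is a 1.2-fold lower number from compound 3 to compound 4 (0.09 log units; within the scatter). For compound 4 the estimated value is 520 umol/kg, with an expected range from 270 umol/kg to 950 umol/kg.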

Compound 4, dose for half-maximal effect: > 514 umol/kg
Compound 4: only a limit was reported (the forecaster's own chance of this, stated with the estimate: 20%); the middle value is on the limit's open side.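

With 4-chlorophenyl in place of 2-chlorophenyl on the double-bonded chain carbon, compound 4 in this assay gives > 514 umol/kg as a limit, so this change of the chlorophenyl group yields no number for this place. The steps to compound 4 from compound 3 and from compound 1 cannot be read, and whether the change from 2-chlorophenyl to 4-chlorophenyl alters the dose remains undecided. Going by these compounds alone, the only readable step is an at least 1.0-fold higher number from compound 2 to compound 4 (0.01 log units; that floor lies within the scatter) and is only a floor, so it does not set 4-chlorophenyl apart from 3-bromophenyl.

The compounds shown leave open how an unsubstituted phenyl would compare at this place. They also leave open whether a phenyl carrying an amine or a carboxylic acid would give a dose clearly apart from those of the halogen-bearing compounds.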